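Bromine in place of a second aromatic ring

The source may report more compounds than this note shows. Statements on the series, on what has been measured and on what is new or still open speak of the compounds shown alone.

Measured compounds:
compound 1 `Cc1ccc(-c2ccccc2S(=O)(=O)N2CCC(N3CCC(C)CC3)CC2)cc1`: 366 nM
compound 2 `Cc1cc(C)c(S(=O)(=O)N2CCC(N3CCC(O)CC3)CC2)c(C)c1`: 106 nM
compound 3 `Cc1cc(C)c(S(=O)(=O)N2CCC(C(=O)N3CCC(C)CC3)CC2)c(C)c1`: > 5000 nM

Among the measured compounds shown here, in a functional assay on DLD-1 cells (Homo sapiens) for antiproliferative activity, read by CellTiter-Glo, with a stated time of 72 h (a higher number here means a weaker inhibitor, a lower number a stronger inhibitor), compound 1 gives 366 nM, the higher of the two numbers known here; the nearest is compound 2 at 106 nM. For compound 3 the assay reports only a limit, > 5000 nM. For the measured compounds named here, the one step measured within one place, an at least 47-fold higher number from compound 2 to compound 3 (1.67 log units; beyond the scatter), concerns a saturated ring carbon, not the aromatic ring.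

Compound 4 `CC1CCN(C2CCN(S(=O)(=O)c3ccccc3Br)CC2)CC1` differs from compound 1 by bromo in place of 4-methylphenyl on an aromatic carbon. Going by the values given here, no measured step touches this aromatic position, so no direction is firmly indicated. Compound 4 is therefore estimated near 400 nM, with a range from 100 nM to 2000 nM. That expectation amounts to a step of a 1.1-fold higher number from compound 1 to compound 4 (0.04 log units; within the scatter).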

Compound 4, half-maximal inhibitory concentration: 3 nM
Estimate against measurement, compound 4: 130-fold (2.12 log units) above, outside the stated range (below it).
By their numbers in this assay, from the lowest: compound 4; then compound 2; then compound 1. At a limit, above all of these: compound 3.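

Bromo in place of 4-methylphenyl gives a 120-fold lower number from compound 1 to compound 4 (2.09 log units; beyond the scatter) in this assay, so this aromatic position, untouched by the earlier step, strongly affects the read-out. A second aromatic ring is not needed here, and a single bromine atom does far better than the 4-methylphenyl group on the core of compound 1. Nothing measured here accounts for the size of this step.

Going by these compounds, it remains open whether bromine is special at this aromatic carbon, or whether chlorine, a methoxy group or an amine would give a similarly low number.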